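Working notes: 4-fluorophenyl to 4-chlorophenyl

A few compounds are considered here, and "the series" means these few. Any claim that something is new, unique, unknown or untested is made for them only; others in the source may bear on it.

In a functional assay on MCF7 cells (Homo sapiens) for antiproliferative activity, read by MTT assay, with a stated time of 24 h (a higher number here means a weaker inhibitor, a lower number a stronger inhibitor), compound 1 (`COc1ccc(-c2noc(C3CCNCC3)n2)cc1OC1CCCC1`) gives 3880 nM. Among the measured compounds shown here, compound 2 (`COc1ccc(-c2noc(-c3ccc(F)cc3)n2)cc1OC1CCCC1`) gives 3880 nM, level with compound 1, its nearest neighbour and the only other measured compound.

The next compound is compound 3 (`COc1ccc(-c2noc(-c3ccc(Cl)cc3)n2)cc1OC1CCCC1`), with chloro in place of fluoro on an aromatic carbon of the 4-fluorophenyl group, para to a large group: chloro in place of fluoro on an aromatic carbon.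

For the measured compounds named here, no measured step touches this halogen, so the data hold no direct precedent. Going by the values given here, the single measured step bears on it only indirectly: 4-fluorophenyl in place of piperidin-4-yl on an aromatic carbon gave no change at the digits printed from compound 1 to compound 2 (within the scatter). That replacement exchanged a whole ring, whereas the present one exchanges a single atom. On the strength of that step, no shift beyond the scatter is expected in this assay, and no direction is favoured. The expected size of the step is a 1.1-fold lower number from compound 2 to compound 3 (0.03 log units; within the scatter). The estimate for compound 3 is 3600 nM, with an expected range of 1500 nM to 8000 nM.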

Compound 3, half-maximal inhibitory concentration: 174000 nM
The estimate for compound 3 lay 48-fold (1.68 log units) below the measured number; the whole stated range lies below it.
By their numbers in this assay, from the lowest: compounds 1 and 2 (each within the scatter of the next); then compound 3.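

In this assay, the position para to a large group on the aromatic ring proves sensitive to the identity of its halogen: chloro in place of fluoro gives a 45-fold higher number from compound 2 to compound 3 (1.65 log units; beyond the scatter), although the exchange swaps one heavy atom for another and leaves the counted hydrogen-bond donors, acceptors and net charge unchanged. The level result for compound 2 therefore does not carry over to every 4-halophenyl group: 4-fluorophenyl in place of piperidin-4-yl gave no change at the digits printed from compound 1 to compound 2 (within the scatter), whereas 4-chlorophenyl in the same place gives a 45-fold higher number from compound 1 to compound 3 (1.65 log units; beyond the scatter). No measurement at hand accounts for this large gap between the two halogens.

From the compounds shown here alone, whether the loss is confined to chloro or also appears with bromo, methyl or methoxy at this position remains open, as does whether an unsubstituted phenyl would read like compound 2 or like compound 3. Also open is how a nitrile, an amine or a carboxylic acid would read there, with only fluoro and chloro shown at this position so far.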